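The compounds below may be only part of what the source reports. "The series", "measured", "known", "first", "only" and "open" are said of these compounds alone.

Working notes on a small series measured in a functional assay on the whole organism with Mus musculus as the target; a lower number here means that less compound is needed, a higher number that more compound is needed for the effect. Compound 1 (`C[C@@H](NCc1ccc(COc2ccccc2)cc1)C(N)=O`) gives 40.3 mg/kg, and compound 2 (`C[C@@H](NCc1ccc(OCCc2ccccc2)cc1)C(N)=O`) gives 24.9 mg/kg. These two values lie within the usual scatter of each other, so the numbers do not separate compound 2 from compound 1.

Compound 3 (`C[C@@H](NCc1ccc(OCC2CC2)cc1)C(N)=O`) has not yet been measured in this assay. It carries cyclopropyl in place of benzyl on a saturated chain carbon bound to an oxygen on an aromatic ring. Among the measured compounds shown here, the series holds no measured step for a change of this kind and only two values to anchor it, so any expectation here is loose. A modest move towards a higher number is expected, meaning that more compound would be needed, with a size close to the usual scatter. A result with no real change would not be surprising. The estimated change is a 1.9-fold higher number from compound 2 to compound 3 (0.29 log units; within the scatter). For compound 3 the expected value is 48 mg/kg, with an estimated range of 20 mg/kg to 115 mg/kg.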

Compound 3, dose for half-maximal effect: 124 mg/kg
Compound 3: middle estimate off by 2.6-fold (0.41 log units), on the low side; measured number above the stated range.
By their numbers in this assay, from the lowest: compounds 2 and 1 (each within the scatter of the next); then compound 3.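

In this assay, among the compounds shown here, cyclopropyl in place of benzyl on a saturated chain carbon bound to an oxygen on an aromatic ring gives a 5.0-fold higher number from compound 2 to compound 3 (0.70 log units; beyond the scatter), the first step beyond the scatter, and it shows that the group at this place can affect the dose needed, which the two earlier values, lying within the scatter of each other, could not show. The step swaps benzyl, with 7 heavy atoms and a six-membered aromatic ring, for cyclopropyl, with 3 heavy atoms and a three-membered non-aromatic ring, so group size and ring type change together and this single step cannot separate them. No measured evidence here bears on the reason for the step.

The compounds shown leave open whether the aromatic ring or the number of carbons matters more at this place, a question that cyclohexylmethyl in place of cyclopropyl, or a pyridylmethyl group in place of benzyl, could help to settle. They also leave open how an open-chain group such as n-butyl would compare with cyclopropyl.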